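A Methoxy for a Chloro on a Weak Cytotoxic Core

The source may hold more compounds than are shown below. What is called first, only, known or untested is meant among the compounds shown, and "the series" means these compounds.

Measured compounds:
compound 1, `FC(F)(F)c1ccc(CSc2nc(Nc3ccccc3)c3ccccc3n2)cc1`, gives 44000 nM in a functional assay on MCF7 cells (Homo sapiens) for cytotoxicity, read by MTT assay, with a stated time of 72 h; a lower number here means a stronger inhibitor, a higher number a weaker inhibitor.
compound 2, `FC(F)(F)c1ccc(CSc2nc(Nc3ccccc3Cl)c3ccccc3n2)cc1`, reaches only the limit > 50000 nM in this assay.

Compound 2 therefore stands at the weak end of what has been measured: its result is a limit of the assay, not a number, so only a floor is known (the limit of > 50000 nM in this assay, at which 1 of the 2 values shown sits). Compound 3, `COc1ccccc1Nc1nc(SCc2ccc(C(F)(F)F)cc2)nc2ccccc12`, differs from compound 2 by methoxy in place of chloro on an aromatic carbon. Within the data shown here, the only measured step is an at least 1.1-fold higher number from compound 1 to compound 2 (0.05 log units; that floor lies within the scatter), which puts chloro in place of hydrogen and leaves compound 2 at the limit. Among the measured compounds shown here, no measured step exchanges chloro for methoxy, so a number no higher from compound 2 to compound 3 (the limit leaves the size open) is expected to be small, with a strong chance that compound 3 also lands at the limit. Compound 3 is estimated at 50000 nM, within 20000 nM to 150000 nM.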

Compound 3, half-maximal inhibitory concentration: > 50000 nM
Compound 3 ended at the assay's limit; the forecaster's own chance of this, stated with the estimate: 60%; the middle value lies on the limit itself.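

In this assay, a second group on this aromatic carbon, ortho to a large group, behaves like the first: compound 3, with methoxy, also ends at a limit of the assay rather than at a number. Methoxy in place of hydrogen gives an at least 1.1-fold higher number from compound 1 to compound 3 (0.05 log units; that floor lies within the scatter), so neither chloro nor methoxy here has produced a readable gain in strength, and compound 1 remains the only one of the three with an actual number, 44000 nM. The exchange of chloro for methoxy itself cannot be read, because both results are limits: the limit of > 50000 nM in this assay, at which 2 of the 3 values shown sit.

From the compounds shown here alone, how far compound 2 and compound 3 lie beyond that limit remains open. So does whether an amine or a carboxylic acid on this carbon would bring a value back within the readable range.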